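A fluoro-to-methyl swap on a dopamine receptor agonist

This account rests on a few compounds, and the source may have more. Where it says the series, first, only, none or still open, it means among the compounds named here.

Of the compounds shown here, three have been tested in a functional assay on HEK293 cells for agonist activity at D(4) dopamine receptor (Homo sapiens), read by FLIPR; a lower number here means a smaller maximal response, a higher number a larger maximal response. Compound 1 `Cc1cc(C(=O)NCN2CCC(c3cccc[n+]3[O-])CC2)ccc1F` gives 67%. Compound 2 `Cc1cc(C)cc(NC(=O)CN2CCC(c3cccc[n+]3[O-])CC2)c1` gives 76%, a difference from compound 1 that lies within the usual scatter. Compound 3 `Cc1cccc(NC(=O)CN2CCC(c3ccc(O)cn3)CC2)c1` gives 83%, which stands beyond the scatter above compound 1. No pair among these three differs in only one place, so no measured step guides the next change.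

Compound 4 `Cc1ccc(C(=O)NCN2CCC(c3cccc[n+]3[O-])CC2)cc1C` differs from compound 1 by methyl in place of fluoro on an aromatic carbon. Among the measured compounds shown here, with no directly comparable step known, the change from compound 1 to compound 4 is expected to be small, a number 3 percentage points higher from compound 1 to compound 4 (within the scatter), and not beyond the scatter in either direction. Compound 4 is therefore estimated at 70% in this assay, with a likely range from 55% to 85%.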

Compound 4, largest response reached (reported as efficacy), in percent of the reference or control that the assay uses: 65%
Compound 4: middle estimate off by 5 percentage points, on the high side; measured number inside the range.
By their numbers in this assay, from the lowest: compounds 4, 1, 2 and 3 (each within the scatter of the next, the first and the last beyond it).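

In this assay, among the compounds shown here, the first one-place step, 4-fluoro-3-methylphenyl to 3,4-dimethylphenyl, is a number 2 percentage points lower from compound 1 to compound 4 (within the scatter) and so separates fluoro from methyl at this position on the aromatic ring by no more than the ordinary scatter. Maximal response therefore stays level across this particular swap, though a single step says nothing about other groups. No measurement at hand offers a reason for this. 

As far as these compounds go, whether a bulkier group such as trifluoromethyl or methoxy would shift the response here remains open. So does the effect of a hydroxyl or an amine at the same place.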